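The source may hold more compounds than are shown below. What is called first, only, known or untested is meant among the compounds shown, and "the series" means these compounds.

Notes on the series in an ADME assay on MCF-10A cells (Homo sapiens) for antiproliferative activity, read by sulforhodamine B assay, with a stated time of 48 h; a lower number here means a stronger inhibitor, a higher number a weaker inhibitor. Compound 1 `C[C@H]1N=C2C[C@H]3C[C@H](C3(C)C)[C@@]2(C)OC1=O` is the reference. In this assay compound 1 gives > 1800000 nM, a limit of the assay rather than a number. Its mirror image, compound 2 `C[C@@H]1N=C2C[C@@H]3C[C@@H](C3(C)C)[C@]2(C)OC1=O`, differs from it only in the configuration as drawn. In this assay compound 2 gives > 2000000 nM, again a limit. Compound 3 `CC1(C)[C@H]2CC3=NCC(=O)O[C@]3(C)[C@@H]1C2` carries hydrogen in place of methyl on a saturated ring carbon. In this assay compound 3 gives > 2000000 nM, also a limit. The step that the two limits leave unreadable from compound 1 to compound 2 is therefore unreadable, as is a step that the two limits leave unreadable from compound 1 to compound 3; none of the three compounds returns a measurable number (the limit of > 1800000 nM in this assay, at which 1 of the 3 values shown sits, (the limit of > 2000000 nM in this assay, at which 2 of the 3 values shown sit)). Compound 1 thus stands at the limit, together with the other two.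

Compound 4 `CC(C)(C)OC(=O)CC[C@H]1N=C2C[C@H]3C[C@H](C3(C)C)[C@@]2(C)OC1=O` is the next entry. It differs from compound 1 by (tert-butoxycarbonyl)methyl in place of hydrogen on a saturated chain carbon bound to a saturated ring carbon. Among the compounds with values here, no measured step bears directly on this change: the two steps recorded, from compound 1 to compound 2 and from compound 1 to compound 3, are both without a readable size because the limit of > 1800000 nM in this assay, at which 1 of the 3 values shown sits, and the limit of > 2000000 nM in this assay, at which 2 of the 3 values shown sit, cap every value. With everything so far sitting at a limit, the expectation for compound 4 in this assay is a step that the limit leaves unreadable from compound 1 to compound 4, that is, nothing beyond the scatter. Compound 4 is expected to give 2000000 nM, within a range from 500000 nM to 6000000 nM, most likely reported once more only as a limit.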

Compound 4, half-maximal inhibitory concentration: > 1200000 nM
Compound 4 was reported as a limit; the forecaster's own chance of this, stated with the estimate: 85%; the middle value does not contradict the limit.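

In this assay compound 4 gives > 1200000 nM, a limit and not a number. With compound 1 also at a limit, no step can be read between the two. The compounds shown leave open whether any compound of this kind gives a measurable value in this assay, and whether (tert-butoxycarbonyl)methyl in place of hydrogen changes activity at all.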